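A Second Methoxy on a Shared Biaryl Scaffold

The source may hold more compounds than are shown below. What is called first, only, known or untested is meant among the compounds shown, and "the series" means these compounds.

Of the compounds shown here, three have been measured in a functional assay on LoVo cells (Homo sapiens) for inhibition, read by colorimetric assay and MTT assay, with a stated time of 72 h; a lower number here means a stronger inhibitor, a higher number a weaker inhibitor. Compound 1 `C=CCCCCOc1ccccc1-c1cnc(OCCC=C)n1C` gives 12000 nM, while compound 2 `C=CCCCCOc1ccc(OC)cc1-c1cnc(OCCC=C)n1C` gives 33000 nM. The change between them, (methoxy in place of hydrogen on an aromatic carbon), produced a 2.8-fold higher number from compound 1 to compound 2 (0.44 log units; beyond the scatter). Compound 3 `C=CCCCCOc1ncc(-c2ccccc2OC)n1C` gives 4000 nM, the lowest number of the three; the difference between its core and that of compound 1 is not broken down here.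

Compound 4 `C=CCCCCOc1ncc(-c2cccc(OC)c2OC)n1C` has not yet been measured. It differs from compound 3 by methoxy in place of hydrogen on an aromatic carbon. This is the same kind of change as that from compound 1 to compound 2, but not the same: in compound 2 the entering methoxy stands meta to a large group and para to a (hex-5-en-1-yl)oxy group, whereas in compound 4 it stands ortho to a methoxy group and meta to a large group. In this assay, for the measured compounds named here, the step of a 2.3-fold higher number from compound 3 to compound 4 (0.35 log units; beyond the scatter) is expected, a weakening of comparable size, because a 2.8-fold higher number from compound 1 to compound 2 (0.44 log units; beyond the scatter) is the only precedent available. On that basis compound 4 is estimated at 9000 nM, within a range from 3000 nM to 30000 nM.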

Compound 4, half-maximal inhibitory concentration: 11000 nM
Estimate against measurement, compound 4: 1.2-fold (0.09 log units) below; the measured number falls inside the stated range.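

In this assay, methoxy in place of hydrogen on an aromatic carbon gave a 2.8-fold higher number from compound 3 to compound 4 (0.44 log units; beyond the scatter), a weakening on the core of compound 3 like the one already seen on the core of compound 1. The two steps agree in size: the same change on two cores in this assay, a 2.8-fold higher number (0.44 log units; beyond the scatter) from compound 1 to compound 2 and a 2.8-fold higher number (0.44 log units; beyond the scatter) from compound 3 to compound 4, 1.0-fold (0.00 log units) apart, within the scatter of two such steps. This shows that within these two pairs the change carried from one core to the other with its size intact, even though in compound 4 the methoxy stands ortho to a methoxy group, but two pairs do not establish a rule for other cores or other ring positions, and they give no cause for the weakening.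

As far as these compounds go, it remains open whether a different group on the same aromatic carbon, such as a hydroxyl, a fluorine or an amine, would raise the number as methoxy does or lower it. Also open, from the compounds shown here alone, is whether a carboxylic acid or a shorter chain in place of the (hex-5-en-1-yl)oxy group would alter the size of this step.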